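This account rests on a few compounds, and the source may have more. Where it says the series, first, only, none or still open, it means among the compounds named here.

Working notes on the series in a functional assay on T47D cells (Homo sapiens) for antiproliferative activity, with a stated time of 72 h; on this read-out higher numbers stand for weaker inhibition and lower numbers for stronger inhibition.

Compound 3 `C#CCSc1cnc2ccccc2c1SCC#CCCl` gives 5.8 ug/mL. Among the three numbers so far it stands second highest; its nearest neighbour is compound 1 `OCC#CCSc1cnc2ccccc2c1SCC#CCCl`, which gives 5.3 ug/mL, and the furthest is compound 2 `CCOC(=O)OCC#CCSc1c(SC)cnc2ccccc12`, which gives 34.2 ug/mL. Among the measured compounds shown here, the one step measured in one place, a 1.1-fold higher number from compound 1 to compound 3 (0.04 log units; within the scatter), concerns the chain on the other sulfur and lies within the scatter.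

Compound 4 `CSc1cnc2ccccc2c1SCC#CCCl` is the next step: hydrogen in place of ethynyl on a saturated chain carbon bound to a sulfur. The change sits on the same sulfur-bound chain that was shortened in the step from compound 1 to compound 3, so that step is the only one that bears directly on it, and it was small. For the measured compounds named here, compound 2 carries the same methylsulfanyl group as compound 4, but its other chain is a different one, so no single step links it to compound 3; its number is simply higher than that of compound 3 and compound 1 by a margin beyond the scatter. Weighing the small step against the higher number of compound 2, a modest rise in the number is expected for compound 4, a 1.6-fold higher number from compound 3 to compound 4 (0.19 log units; within the scatter), with wide uncertainty. The value expected for compound 4 is 9 ug/mL, between 3.5 ug/mL and 25 ug/mL.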

Compound 4, concentration for 50% inhibition: 3.9 ug/mL
Compound 4: the middle estimate sits 2.3-fold (0.36 log units) above what was measured; the measured number falls inside the stated range.
By their numbers in this assay, from the lowest: compounds 4, 1 and 3 (each within the scatter of the next); then compound 2.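

In this assay the chain on this sulfur can now be reduced to its smallest form, propargyl to methyl, and the result is a 1.5-fold lower number from compound 3 to compound 4 (0.17 log units; within the scatter) and likewise a 1.4-fold lower number from compound 1 to compound 4 (0.13 log units; within the scatter) when the starting chain carries 3-hydroxyprop-1-yn-1-yl. On a saturated chain carbon bound to a sulfur, neither ethynyl nor 3-hydroxyprop-1-yn-1-yl makes a difference that can be read against hydrogen, so the triple bond of this chain is not needed to hold the number at this level in the compounds shown. Among the compounds shown here, the only step beyond the scatter lies at the other chain, where chloro in place of (ethoxycarbonyl)oxy on a saturated chain carbon bound to a triple-bonded carbon gives an 8.8-fold lower number from compound 2 to compound 4 (0.94 log units; beyond the scatter) and moves attention from the methylsulfanyl side to that chain end.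

The compounds shown leave open whether an amine or a carboxylic acid on this sulfur-bound chain, or a longer saturated chain there, would keep the number in the same range, and whether bromo or hydroxy at the other chain end would match chloro. No accompanying measurement offers an explanation for any of these steps.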